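Three Compounds at One Limit and a Fourth Expected There

The compounds below may be only part of what the source reports. "The series", "measured", "known", "first", "only" and "open" are said of these compounds alone.

Compound 1 `COc1ccc(/C=C/[C@@](C)(/C=C/c2ccc(O)cc2)CCC=C(C)C)cc1` — in a functional assay on NALM-6 cells (Homo sapiens) for cytotoxicity, with a stated time of 72 h (a higher number here means that more compound is needed for the effect, a lower number that less compound is needed), compound 1 gives > 43400 nM, a limit of the assay.
Compound 2 `CC(C)=CCC[C@@](C)(/C=C/c1ccccc1)/C=C/c1ccc(O)cc1` — in this assay compound 2 gives > 43400 nM, again a limit.
Compound 3 `C=C[C@@](C)(/C=C/c1ccc(Nc2ccc(OC)cc2)cc1)CCC=C(C)C` — in this assay compound 3 gives > 43400 nM, also a limit.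

All three measured compounds sit at the limit of > 43400 nM in this assay, at which 3 of the 3 values shown sit, so none of the three gives a number. Compound 1 differs from compound 2 by methoxy in place of hydrogen on an aromatic carbon, and the step that the two limits leave unreadable from compound 2 to compound 1 cannot be read, since both ends are limits. The difference between the cores of compound 2 and compound 3 is not broken down here.

Compound 4 `C=C[C@@](C)(/C=C/c1ccc(Nc2ccc(OC)c(OC)c2)cc1)CCC=C(C)C` has not yet been measured. It differs from compound 3 by methoxy in place of hydrogen on an aromatic carbon. This is the same kind of change as that from compound 2 to compound 1, not the same: in compound 4 the methoxy sits ortho to a methoxy group and meta to a large group, while in compound 1 it sits para to a large group.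

Because compound 3 gives > 43400 nM and the earlier methoxy step that the two limits leave unreadable from compound 2 to compound 1 is unreadable, compound 4 is expected to remain at the limit as well. The step that the limit leaves unreadable from compound 3 to compound 4 is estimated to be small. Compound 4 is expected to give about 60000 nM, most likely between 20000 nM and 150000 nM.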

Compound 4, half-maximal effective concentration: > 43400 nM
Compound 4 gave a limit, no number (the forecaster's own chance of this, stated with the estimate: 85%); the middle value does not contradict the limit.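

Compound 3 and compound 4 both stand at a limit in this assay, so no new step can be read between them, and the same holds for all four compounds: the limit of > 43400 nM in this assay, at which 4 of the 4 values shown sit.

The compounds shown leave open whether any of these structures gives a number in this assay, and what methoxy in place of hydrogen on an aromatic carbon does to that number.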